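The source may report more compounds than this note shows. Statements on the series, on what has been measured and on what is new or still open speak of the compounds shown alone.

Working notes on the series. The shared core carries a carbon chain linking the amide to the sulfonamide portion; the compounds differ in chain length and in the aryl group on the sulfonamide nitrogen. In a functional assay on HeLa cells (Homo sapiens) for inhibition, read by CCK-8 assay, with a stated time of 72 h (on this read-out lower numbers stand for stronger inhibition and higher numbers for weaker inhibition), compound 1 `O=C(/C=C/c1cccnc1)NCCCCc1ccc(S(=O)(=O)Nc2ccccc2)cc1` gives 184 nM. Compound 2 `O=C(/C=C/c1cccnc1)NCCCCCc1ccc(S(=O)(=O)Nc2ccccc2)cc1` has a longer chain, and in this assay compound 2 gives 333 nM. Compound 3 `Cc1ccc(NS(=O)(=O)c2cccc(CCCCCCNC(=O)/C=C/c3cccnc3)c2)cc1` carries a 4-methylphenyl on the sulfonamide nitrogen and the longest chain; in this assay compound 3 gives 38.8 nM, the lowest number of the three, with both gaps to compound 1 and to compound 2 beyond the scatter, so compound 3 is the most potent measured member.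

Compound 4 `O=C(/C=C/c1cccnc1)NCCCCCCc1cccc(S(=O)(=O)Nc2ccc(C(F)(F)F)cc2)c1` differs from compound 3 in one place: trifluoromethyl in place of methyl on an aromatic carbon. Among the compounds with values here, no measured pair in the set shows this exchange, so the data give no direction for it. Since compound 3 gives 38.8 nM and everything else is retained, compound 4 is expected to sit close to it, with a step of a 1.2-fold higher number from compound 3 to compound 4 (0.06 log units; within the scatter) in this assay, none beyond the scatter. Compound 4 is estimated at 45 nM, within 12 nM to 170 nM.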

Compound 4, half-maximal inhibitory concentration: 1450 nM
Beside the measured number, compound 4's estimate is 32-fold (1.51 log units) below it; the measured number lies above the stated range.
By their numbers in this assay, from the lowest: compound 3; then compounds 1 and 2 (each within the scatter of the next); then compound 4.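

Going from 4-methylphenyl to 4-(trifluoromethyl)phenyl gives a 37-fold higher number from compound 3 to compound 4 (1.57 log units; beyond the scatter) in this assay, and this is the first measured exchange at this position. With everything else retained, the read-out proves highly sensitive to the group held on this aromatic carbon, and the long chain shared by compound 3 and compound 4 is not enough on its own to secure a low number. Nothing at hand bears on the reason for a step of this size.

As far as these compounds go, what fluorine, chlorine, methoxy or an amine would give at this place stays open, so it is unclear whether trifluoromethyl is a lone exception or part of a graded trend. Also open, from the compounds shown here alone, is whether the same exchange carries a step of similar size on a shorter chain.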